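This account rests on a few compounds, and the source may have more. Where it says the series, first, only, none or still open, it means among the compounds named here.

Measured so far: compound 1 `CCCn1c(SCc2cc([N+](=O)[O-])ccc2OC)nc2cc(NC(=O)NC(C)(C)C)cc(C(=O)NCc3ccccc3)c21` with 120 nM and compound 2 `CCCn1c(SCc2cc([N+](=O)[O-])ccc2OC)nc2cc(NC(=O)NC(C)(C)C)cc(C(=O)NCc3cccnc3)c21` with 69 nM.

In an assay on isolated protein for inhibition of Gonadotropin-releasing hormone receptor (Homo sapiens) (on this read-out higher numbers stand for weaker inhibition and lower numbers for stronger inhibition), compound 2 gives 69 nM and compound 1 gives 120 nM; the single step between them, a 1.7-fold lower number from compound 1 to compound 2 (0.24 log units; within the scatter), lies within the scatter, so on the numbers shown compound 2 and compound 1 are not separated in any reliable way. Compound 3 `CCCn1c(SCc2cc([N+](=O)[O-])ccc2OC)nc2cc(NC(=O)NC(C)(C)C)cc(C(=O)NCCCN(C)C)c21` differs from compound 2 by 2-(dimethylamino)ethyl in place of pyridin-3-yl on a saturated chain carbon bound to an amide-type nitrogen. Going by the values given here, the only measured step at that place, a 1.7-fold lower number from compound 1 to compound 2 (0.24 log units; within the scatter), swapped one six-membered aromatic ring for another and left the number essentially unchanged; no measured step exchanges a ring for a chain, so nothing bears directly on this change. With a step of a 1.4-fold higher number from compound 2 to compound 3 (0.16 log units; within the scatter) expected, and the earlier swap having stayed inside the scatter, a modest move is anticipated rather than a large one. Compound 3 is therefore estimated at 100 nM in this assay, with a range from 30 nM to 350 nM.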

Compound 3, half-maximal inhibitory concentration: 170 nM
Beside the measured number, compound 3's estimate is 1.7-fold (0.23 log units) below it; the range from low to high includes it.
By their numbers in this assay, from the lowest: compounds 2, 1 and 3 (each within the scatter of the next, the first and the last beyond it).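

In this assay, going by these compounds alone, exchanging a ring for a chain on a saturated chain carbon bound to an amide-type nitrogen gives the first step at this place to pass the scatter, a 2.5-fold higher number from compound 2 to compound 3 (0.39 log units; beyond the scatter), so the number does respond to this group. The same chain set against phenyl gives only a 1.4-fold higher number from compound 1 to compound 3 (0.15 log units; within the scatter), so 2-(dimethylamino)ethyl is separated from pyridin-3-yl but not from phenyl, which limits any reading of ring against chain to a single pair. Nothing available bears on why the step arises.

On these data alone, whether the change follows the loss of the ring or the dimethylamino end of the chain remains open. How a plain butyl chain, a primary amine or a carboxylic acid would compare at this place is also unsettled.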